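Swapping a Phenyl for a Tert-Butyl on the Aromatic Arm

The compounds below may be only part of what the source reports. "The series", "measured", "known", "first", "only" and "open" are said of these compounds alone.

Of the compounds shown here, two built on the same core have been measured so far, and they differ only in the aromatic arm attached to the shared core. Compound 1, with the structure `O=S(=O)(NCCNCc1cccc2ccccc12)c1cc(C(F)(F)F)cc(C(F)(F)F)c1`, is the weaker of the pair: in a functional assay on Capan-2 cells (Homo sapiens) for inhibition, read by MTT assay, with a stated time of 72 h (a lower number here means a stronger inhibitor of growth, a higher number a weaker inhibitor of growth), compound 1 gives 21000 nM. Compound 2, with the structure `O=S(=O)(NCCNCc1ccc(-c2ccccc2)cc1)c1cc(C(F)(F)F)cc(C(F)(F)F)c1`, does clearly better, and in this assay compound 2 gives 2400 nM, the lower of the two numbers; the gap between compound 2 and compound 1 lies well beyond the usual scatter of repeated measurements, so compound 2 is the stronger growth inhibitor of the two.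

Compound 3, with the structure `CC(C)(C)c1ccc(CNCCNS(=O)(=O)c2cc(C(F)(F)F)cc(C(F)(F)F)c2)cc1`, has not yet been measured. It is compound 2 with one change: tert-butyl in place of phenyl on an aromatic carbon. Within the data shown here, no measured pair of compounds shows this exact swap, so its effect is unknown from the data at hand. A group of similar bulk replaces another in the same position, and the step is expected to be small, most likely not beyond the scatter or, if anything, a modest weakening of growth inhibition, which is an estimated change of a 1.5-fold higher number from compound 2 to compound 3 (0.16 log units; within the scatter). Compound 3 is therefore estimated at 3500 nM, with a likely range from 1200 nM to 12000 nM.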

Compound 3, concentration for 50% growth inhibition: 13000 nM
For compound 3 the middle estimate is 3.7-fold (0.57 log units) below the measured one; measured number above the stated range.
By their numbers in this assay, from the lowest: compound 2; then compounds 3 and 1 (each within the scatter of the next).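

In this assay the group at this place on the aromatic ring clearly matters: tert-butyl in place of phenyl gives a 5.4-fold higher number from compound 2 to compound 3 (0.73 log units; beyond the scatter), so two groups with no hydrogen-bond donors or acceptors and no net charge are still not interchangeable here. Phenyl has 6 heavy atoms and a six-membered aromatic ring, whereas tert-butyl has 4 heavy atoms and no ring, so the change that weakens growth inhibition removes both a ring and some carbon. The comparison of the whole arms gives a 1.6-fold lower number from compound 1 to compound 3 (0.21 log units; within the scatter), which means that the tert-butyl compound and the naphthalen-1-yl compound cannot be told apart, and among these three compounds only compound 2 stands out.

The available data offer no explanation for the loss seen on leaving phenyl. As far as these compounds go, it remains open whether the aromatic ring itself is what counts at this place, a question that a cyclohexyl group, with a ring that is not aromatic, or a pyridyl group, with a nitrogen in the aromatic ring, could help to answer.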